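Swapping Fluorines on a Benzyl Piperazine Tail

The source may report more compounds than this note shows. Statements on the series, on what has been measured and on what is new or still open speak of the compounds shown alone.

Compound 2 `CCN(CC)c1ccc2cc(C(=O)c3ccc(N4CCN(C(=O)CN5CCN(Cc6ccc(F)c(F)c6)CC5)CC4)cc3)oc2c1` carries a 3,4-difluorobenzyl group on an amine nitrogen in a ring. In a functional assay on HeLa cells (Homo sapiens) for cytotoxicity, read by MTT assay, with a stated time of 48 h (a lower number here means a stronger inhibitor, a higher number a weaker inhibitor), compound 2 gives 6400 nM. For the measured compounds named here, compound 1 `CCN(CC)c1ccc2cc(C(=O)c3ccc(N4CCN(C(=O)CN5CCN(C(=O)/C=C/c6ccccc6)CC5)CC4)cc3)oc2c1`, which instead carries a (2-phenylethenyl)carbonyl group at that nitrogen, gives 5260 nM in this assay, and the single measured step, a 1.2-fold higher number from compound 1 to compound 2 (0.09 log units; within the scatter), shows the two numbers sitting within the scatter of each other, so neither compound can be called stronger or weaker. Compound 3 `CCN(CC)c1ccc2cc(C(=O)c3ccc(N4CCN(C(=O)CN5CCN(Cc6ccc(C(F)(F)F)cc6)CC5)CC4)cc3)oc2c1` keeps the shared core and differs from compound 2 in one place: 4-(trifluoromethyl)phenyl in place of 3,4-difluorophenyl on a saturated chain carbon bound to an amine nitrogen in a ring. Going by the values given here, no measured step covers this exact exchange, and the one step known at this position moved the number little, so a change beyond the scatter is not expected here either. Compound 3 is therefore estimated to give about 6500 nM, between 3000 nM and 14000 nM, an expected step of a 1.0-fold higher number from compound 2 to compound 3 (0.01 log units; within the scatter).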

Compound 3, half-maximal inhibitory concentration: > 40000 nM
Compound 3 was reported as a limit; the forecaster's own chance of this, stated with the estimate: 5%; middle value at least 6.1-fold (0.78 log units) from the limit.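

The first step suggested that this nitrogen tolerates quite different groups, but the exchange of 3,4-difluorophenyl for 4-(trifluoromethyl)phenyl shows that it does not tolerate all of them: in this assay, the exchange gives an at least 6.2-fold higher number from compound 2 to compound 3 (0.79 log units; beyond the scatter). Measured against the (2-phenylethenyl)carbonyl group, 4-(trifluoromethyl)benzyl gives an at least 7.6-fold higher number from compound 1 to compound 3 (0.88 log units; beyond the scatter), so compound 3 is weaker than both other compounds, even though a small change on the benzyl ring is all that separates it from compound 2. The reading for compound 3 is a limit of the assay and not a number: the limit of > 40000 nM in this assay, at which 1 of the 3 values shown sits.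

From the compounds shown here alone, the true size of both steps therefore remains open. Also open, going by these compounds, is whether the trifluoromethyl group itself accounts for the loss, a question that an unsubstituted benzyl, 4-fluorobenzyl or 4-methylbenzyl group at this nitrogen could help to answer.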